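Series notes: replacing the azetidine of compound 3

This account rests on a few compounds, and the source may have more. Where it says the series, first, only, none or still open, it means among the compounds named here.

Within the data shown here, compound 3 `CS(=O)(=O)Nc1ccc(CNC(=O)c2ccc(N3CCC3)cc2)c(Cl)c1` gives 13000 nM in an assay on HeLa cells for agonist activity at Bile acid receptor (Homo sapiens), read by a luciferase reporter, with a stated time of 24 h (on this read-out lower numbers stand for an effect already at smaller amounts and higher numbers for an effect only at larger amounts of compound), the highest of the three numbers measured so far; compound 1 `CCS(=O)(=O)Nc1ccc(CNC(=O)c2ccc(C(C)(C)C)cc2)c(Cl)c1` gives 500 nM and compound 2 `CC(C)(C)c1ccc(C(=O)NCc2ccc(NS(=O)(=O)C3CC3)cc2Cl)cc1` gives 1500 nM. Among the measured compounds shown here, the only single-point step measured, a 3.0-fold higher number from compound 1 to compound 2 (0.48 log units; beyond the scatter), concerns the sulfonyl substituent and not the position changed here. Compound 4 `CC(F)(F)c1ccc(C(=O)NCc2ccc(NS(C)(=O)=O)cc2Cl)cc1` differs from compound 3 by 1,1-difluoroethyl in place of azetidin-1-yl on an aromatic carbon. For the measured compounds named here, compounds 1 and 2 carry tert-butyl at that position but also differ from compound 3 at the sulfonyl, so no measured step isolates this change. The expectation for compound 4 is therefore a lower number, toward the range of compounds 1 and 2, estimated as a 6.5-fold lower number from compound 3 to compound 4 (0.81 log units; beyond the scatter). For compound 4 the estimate in this assay is 2000 nM, between 500 nM and 8000 nM.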

Compound 4, half-maximal effective concentration: 1200 nM
Estimate against measurement, compound 4: 1.7-fold (0.22 log units) above, within the range that was stated.
By their numbers in this assay, from the lowest: compound 1; then compounds 4 and 2 (each within the scatter of the next); then compound 3.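

On this assay, the aromatic carbon para to a large group now has its first measured single-point step: an 11-fold lower number from compound 3 to compound 4 (1.03 log units; beyond the scatter). This step, rated large, exceeds the modest sulfonyl step, a 3.0-fold higher number from compound 1 to compound 2 (0.48 log units; beyond the scatter), so this position has the bigger measured effect of the two. Nothing available explains the difference between azetidin-1-yl and 1,1-difluoroethyl. Going by these compounds, whether the lower number comes from losing azetidin-1-yl or from gaining 1,1-difluoroethyl remains open. Also open, on these data alone, is how a trifluoromethyl group or an open-chain dimethylamino group would read at this position.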